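Swapping difluorophenyl isomers against a cytotoxicity ceiling

This account rests on a few compounds, and the source may have more. Where it says the series, first, only, none or still open, it means among the compounds named here.

Measured so far in an ADME assay on Vero cells (Chlorocebus sabaeus) for cytotoxicity, with a stated time of 72 h; on this read-out lower numbers stand for stronger inhibition and higher numbers for weaker inhibition:
Compound 1, `CCOC(=O)c1cc(-c2cccc(OCc3ccccc3)c2)on1`, reaches only a limit of the assay, > 128000 nM.
Compound 2, `CCOC(=O)c1cc(-c2cccc(OCc3cccc(F)c3)c2)on1`, reaches only a limit of the assay, > 128000 nM.
Compound 3, `CCOC(=O)c1cc(-c2cccc(OCc3cccc(F)c3F)c2)on1`, reaches only a limit of the assay, > 128000 nM.

Compound 3 therefore stands at the ceiling of this assay, not at a number, and all three values sit together there (the limit of > 128000 nM in this assay, at which 3 of the 3 values shown sit). The steps between the measured compounds, a step that the two limits leave unreadable from compound 1 to compound 2, a step that the two limits leave unreadable from compound 1 to compound 3 and a step that the two limits leave unreadable from compound 2 to compound 3, are consequently unreadable in size and direction. The change to compound 4, `CCOC(=O)c1cc(-c2cccc(OCc3cc(F)ccc3F)c2)on1`, is 2,5-difluorophenyl in place of 2,3-difluorophenyl on a saturated chain carbon bound to an oxygen on an aromatic ring. Among the measured compounds shown here, no measured step bears readably on it, so no step beyond the scatter is expected in this assay from compound 3 to compound 4, a step that the limit leaves unreadable from compound 3 to compound 4. Compound 4 is accordingly estimated at 200000 nM, within 100000 nM to 500000 nM, most probably again reported as a limit.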

Compound 4, half-maximal inhibitory concentration: > 128000 nM
Compound 4: only a limit was reported; the forecaster's own chance of this, stated with the estimate: 85%; the middle value lies beyond the limit too.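

Compound 4 joins compound 1, compound 2 and compound 3 at the ceiling of this assay, so no step among these compounds can be read: the limit of > 128000 nM in this assay, at which 4 of the 4 values shown sit.

The compounds shown leave open how far beyond that limit each of the four lies, and whether their cytotoxicity differs at all.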